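A few compounds are considered here, and "the series" means these few. Any claim that something is new, unique, unknown or untested is made for them only; others in the source may bear on it.

Measured so far:
compound 1 `CCC(C(=O)N1CCN(c2ccc(C(F)(F)F)cc2)CC1)N1C(=O)CCC1=O` — 0%
compound 2 `CCC(C(=O)N1CCN(c2ccccc2F)CC1)N1C(=O)CCC1=O` — 50%
compound 3 `CCC(C(=O)N1CCN(c2cccc(C)c2)CC1)N1C(=O)CCC1=O` — 75%

All three share one core and differ only in the aryl group on the piperazine nitrogen. Going by the values given here, in a functional assay on the whole organism (strain Swiss) with Mus musculus as the target, in the maximal electroshock model, with a stated time of 1 h, at a dose of 300 mg/kg by the intraperitoneal route (on this read-out lower numbers stand for a weaker effect and higher numbers for a stronger effect at the one dose given), compound 3 stands highest of the three, with compound 2 nearest and compound 1 furthest, and the single one-place step recorded, a number 25 percentage points higher from compound 2 to compound 3 (beyond the scatter), is modest. Compound 1, bearing trifluoromethylphenyl, shows no effect at this dose.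

Compound 4 `CCC(C(=O)N1CCN(c2ccccc2)CC1)N1C(=O)CCC1=O` is the next one: hydrogen in place of methyl on an aromatic carbon. Among the compounds with values here, no measured step bears directly on this change; only the aryl swap from compound 2 to compound 3 hints that aryl substitution moves the read-out. A small loss is therefore expected, a number 25 percentage points lower from compound 3 to compound 4 (beyond the scatter), with compound 4 estimated at 50% (range 25% to 100%).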

Compound 4, a percentage reported as activity, at one dose (the size of the read-out at that dose, not a potency): 75%
The estimate for compound 4 lay 25 percentage points below the measured number, within the range that was stated.
By their numbers in this assay, from the lowest: compound 1; then compound 2; then compounds 3 and 4 (each within the scatter of the next).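

In this assay, the change from 3-methylphenyl to phenyl leaves the read-out flat (no change at the digits printed from compound 3 to compound 4 (within the scatter)), so at this one dose the methyl on the aromatic carbon is not required for the effect. Phenyl also gives a reference for the other two aryl groups, with fluoro giving way to hydrogen (a number 25 percentage points higher from compound 2 to compound 4 (beyond the scatter)) and trifluoromethyl giving way to hydrogen (a number 75 percentage points higher from compound 1 to compound 4 (beyond the scatter)), a much larger step. No measured evidence on these changes is available to explain them.

As far as these compounds go, it remains open how a methoxy group, an amine or a carboxylic acid on the aromatic ring would read out. From the compounds shown here alone, it also remains open whether the fluoro and trifluoromethyl steps follow the group itself or its place on the ring.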